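From Methoxy to Fluoro in Compound 4

A few compounds are considered here, and "the series" means these few. Any claim that something is new, unique, unknown or untested is made for them only; others in the source may bear on it.

In an ADME assay for permeability, using PAMPA, at pH 7.4 (on this read-out lower numbers stand for lower permeability and higher numbers for higher permeability), compound 2 `COc1ccc(NC(=O)Nc2cc(C)nc3ccccc23)cc1OC` gives 552 10^-6 cm/s. That is within the scatter of compound 3 `Cc1ccc(NC(=O)Nc2cc(C)nc3ccccc23)cc1` at 669 10^-6 cm/s. Compound 1 `Cc1cc(NC(=O)Nc2ccc(C(C)(C)C)cc2)c2ccccc2n1` gives 142 10^-6 cm/s, a lower number and beyond the scatter. Compound 4 `COc1ccc(NC(=O)Nc2cc(C)nc3ccccc23)cc1F` keeps the shared core but carries fluoro in place of methoxy on an aromatic carbon, ortho to a methoxy group (fluoro in place of methoxy on an aromatic carbon). Among the measured compounds shown here, the only measured single change is a 4.7-fold higher number from compound 1 to compound 3 (0.67 log units; beyond the scatter), where methyl replaces tert-butyl. That is a different swap, so it gives weak guidance, and no step beyond the scatter is expected in this assay. The expected change is a 1.1-fold higher number from compound 2 to compound 4 (0.04 log units; within the scatter). Compound 4 is estimated at 600 10^-6 cm/s, with a range from 300 10^-6 cm/s to 1150 10^-6 cm/s.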

Compound 4, apparent permeability: 50 10^-6 cm/s
Compound 4: the middle estimate sits 12-fold (1.08 log units) above what was measured; measured number below the stated range.
By their numbers in this assay, from the lowest: compound 4; then compound 1; then compounds 2 and 3 (each within the scatter of the next).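

In this assay, this position proves highly sensitive: placing fluoro in place of methoxy on this aromatic carbon, ortho to a methoxy group, gives an 11-fold lower number from compound 2 to compound 4 (1.04 log units; beyond the scatter). The earlier compounds shown here showed only a change at another place, so they revealed nothing about this one. Nothing measured here gives a reason for the size of this step. The compounds shown leave open whether the step comes from losing methoxy or from gaining fluoro. They also leave open how a chloro or hydroxy group on this same carbon would read.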